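A few compounds are considered here, and "the series" means these few. Any claim that something is new, unique, unknown or untested is made for them only; others in the source may bear on it.

Measured so far in a functional assay on T47D cells (Homo sapiens) for cytotoxicity, read by sulforhodamine B assay, with a stated time of 48 h; a higher number here means a weaker inhibitor of growth, a lower number a stronger inhibitor of growth:
compound 2 `ClCc1cccc(Cn2cnc3nc(Cl)nc(Cl)c32)c1` gives 220 nM;
compound 3 `Nc1nc(Cl)c2ncn(Cc3cccc(CCl)c3)c2n1` gives 6020 nM;
compound 1 `ClCc1ccc(Cn2cnc3c(Cl)ncnc32)cc1` gives "not determined" (no result reported), that is, no result in this assay.

Compound 2 stands at the lowest of the two numbers recorded. The nearest value is that of compound 3, which lies at a higher number, and the gap between the two is beyond the usual scatter. Nothing connects these two compounds by a single structural step, so the gap is only what the two values show, and it cannot be split into parts.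

Compound 4 `ClCc1cccc(Cn2cnc3ncnc(Cl)c32)c1` is not yet measured. It differs from compound 2 in one place (hydrogen in place of chloro on an aromatic carbon). Going by the values given here, no pair of measured compounds shows the effect of such a change, so the direction of the step has to be judged from the series as a whole.

Compound 4 is expected to give 600 nM in this assay, with a likely range from 180 nM to 2000 nM. The expected step from a 2.7-fold higher number from compound 2 to compound 4 (0.44 log units; beyond the scatter) is a modest rise in the number, set wide enough that no change beyond the scatter is also covered.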

Compound 4, concentration for 50% growth inhibition: 210 nM
Compound 4: the middle estimate sits 2.9-fold (0.46 log units) above what was measured; measured number inside the range.
By their numbers in this assay, from the lowest: compounds 4 and 2 (each within the scatter of the next); then compound 3.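

Notes on the series: in this assay, hydrogen in place of chloro on the aromatic carbon between two ring nitrogen atoms gives a 1.0-fold lower number from compound 2 to compound 4 (0.02 log units; within the scatter) and stays within the scatter. Going by these compounds alone, this is the first single-place reading at this position, and it shows that the chloro group there is not required for a number at this level in this assay, with compound 2 and compound 4 reading alike. Nothing measured speaks to why the change leaves the number within the scatter, so the result stands as an observation only.

Hydrogen and chloro are the only two groups compared by a single step at this carbon, so the outcome with a methyl group, a methoxy group or a fluoro group there remains open. Also open, going by these compounds, is what hydrogen would give in place of the chloro group meta to that carbon, which compound 2 and compound 4 both keep, and whether the chloromethyl group on the benzyl ring can give way to a hydroxymethyl group in this same assay.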